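The source may hold more compounds than are shown below. What is called first, only, known or untested is meant among the compounds shown, and "the series" means these compounds.

Measured compounds:
- compound 1, `O=S(=O)(NCC1CCN(CCCc2c[nH]c3ccc(-n4cnnc4)cc23)CC1)c1ccccc1`: 6.2 nM
- compound 2, `c1ccc(CNCC2CCN(CCCc3c[nH]c4ccc(-n5cnnc5)cc34)CC2)cc1`: 1.6 nM
- compound 3, `c1cc(CNC2CCN(CCCc3c[nH]c4ccc(-n5cnnc5)cc34)CC2)co1`: 4.5 nM

All three were tested in an assay on CHO cells for displacement of a labelled ligand from 5-hydroxytryptamine receptor 1D (Homo sapiens); on this read-out lower numbers stand for stronger inhibition and higher numbers for weaker inhibition. Compound 1 shows the highest number of the three; compound 3 sits close, with compound 2 furthest away, as the step of a 3.9-fold lower number from compound 1 to compound 2 (0.59 log units; beyond the scatter) shows, whereas the step of a 1.4-fold lower number from compound 1 to compound 3 (0.14 log units; within the scatter) stays within the scatter.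

Compound 4, `C[C@H](NCC1CCN(CCCc2c[nH]c3ccc(-n4cnnc4)cc23)CC1)c1ccccc1`, has not yet been measured. It differs from compound 1 in one place: 1-phenylethyl in place of phenylsulfonyl on an amine nitrogen. The incoming group is a benzyl carrying one extra carbon, so the closest measured guide is the step of a 3.9-fold lower number from compound 1 to compound 2 (0.59 log units; beyond the scatter), where benzyl replaced the same phenylsulfonyl on the same amine nitrogen and gave a modest lowering. The step of a 2.8-fold higher number from compound 2 to compound 3 (0.45 log units; beyond the scatter) does not touch this position and bears only indirectly.

Compound 4 is therefore expected to fall near compound 2, with an estimated step of a 3.1-fold lower number from compound 1 to compound 4 (0.49 log units; beyond the scatter). The estimate for compound 4 is 2 nM, within a range from 0.8 nM to 5 nM.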

Compound 4, half-maximal inhibitory concentration: 4.4 nM
The estimate for compound 4 lay 2.2-fold (0.34 log units) below the measured number; measured number inside the range.
By their numbers in this assay, from the lowest: compound 2; then compounds 4, 3 and 1 (each within the scatter of the next).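

In this assay, among these compounds, a single methyl on the saturated chain carbon bound to an amine nitrogen and an aromatic carbon changes the result, with a 2.8-fold higher number from compound 2 to compound 4 (0.44 log units; beyond the scatter), so this carbon responds to even a small addition, which the earlier compounds could not show. The 1-phenylethyl group also does not keep the gain seen with benzyl: a 1.4-fold lower number from compound 1 to compound 4 (0.15 log units; within the scatter) and a 1.0-fold lower number from compound 3 to compound 4 (0.01 log units; within the scatter) leave compound 4 level with compound 1 and compound 3. Nothing available explains the effect of this methyl.

From the compounds shown here alone, how the mirror-image form of the 1-phenylethyl group would compare with compound 4 remains open. Going by these compounds, it is also open whether an ethyl group on the same carbon, or a methyl on the amine nitrogen itself, would give a number closer to that of compound 2.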